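The compounds below may be only part of what the source reports. "The series", "measured", "known", "first", "only" and "open" are said of these compounds alone.

In a functional assay on DLD-1 cells (Homo sapiens) for antiproliferative activity, read by CellTiter-Glo, with a stated time of 72 h (a higher number here means a weaker inhibitor, a lower number a stronger inhibitor), compound 1 `CC1CCCN(C2CCN(S(=O)(=O)c3ccc(OC(F)F)cc3)CC2)C1` gives 105 nM. Compound 3 `CC1CCN(C2CCN(C(=O)c3ccc(OC(F)(F)F)cc3)CC2)CC1` gives 426 nM in this assay. Compound 2 `Cc1cc(C)c(S(=O)(=O)N2CCC(C(=O)N3CCC(C)CC3)CC2)c(C)c1` returns only a limit, not a number, and gives > 5000 nM; it thus stands at the weak end of the values shown, sitting at the limit of > 5000 nM in this assay, at which 1 of the 3 values shown sits. Compound 4 `Cc1cc(C)c(S(=O)(=O)N2CCC(c3ccccc3)CC2)c(C)c1` has not yet been measured. It differs from compound 2 in one place: phenyl in place of (4-methylpiperidin-1-yl)carbonyl on a saturated ring carbon. Among the measured compounds shown here, no measured pair in this set isolates such a change, so the size of the step in this assay cannot be read from the data. The step is expected to be a number no higher from compound 2 to compound 4 (the limit leaves the size open), most likely not beyond the scatter and with a fair chance of another limit. Compound 4 is therefore expected near 5000 nM, with a range from 1500 nM to 15000 nM.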

Compound 4, half-maximal inhibitory concentration: > 5000 nM
Compound 4: only a limit was reported (the forecaster's own chance of this, stated with the estimate: 55%); the middle value sits exactly at the limit.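

Compound 2 and compound 4 both return only a limit in this assay, so no step can be read between them: the limit of > 5000 nM in this assay, at which 2 of the 4 values shown sit.

From the compounds shown here alone, what phenyl in place of (4-methylpiperidin-1-yl)carbonyl changes in this assay therefore stays open.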